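From Furan to Benzofuran on a Weak Nucleoside

A few compounds are considered here, and "the series" means these few. Any claim that something is new, unique, unknown or untested is made for them only; others in the source may bear on it.

Compound 3 `Nc1nc(N)c2c(-c3ccco3)cn([C@@H]3O[C@H](CO)[C@@H](O)[C@H]3O)c2n1` stands at > 20000 nM in a functional assay on HCT-116 cells (Homo sapiens), read by MTT assay, with a stated time of 72 h (a higher number here means a weaker inhibitor, a lower number a stronger inhibitor), which is a limit and not a number. This places compound 3 at the limit of > 20000 nM in this assay, at which 1 of the 3 values shown sits.

Compound 4 `Nc1nc(N)c2c(-c3cc4ccccc4o3)cn([C@@H]3O[C@H](CO)[C@@H](O)[C@H]3O)c2n1` differs from it in one place, with 1-benzofuran-2-yl in place of furan-2-yl on an aromatic carbon. Among the measured compounds shown here, no measured step makes this exchange directly. The closest evidence comes from a pair on a different core. Compound 1 `COc1ncnc2c1c(-c1cc3ccccc3o1)cn2[C@@H]1O[C@H](CO)[C@@H](O)[C@H]1O` carries the same 1-benzofuran-2-yl group and gives 13800 nM in this assay. Compound 2 `C#Cc1cn([C@@H]2O[C@H](CO)[C@@H](O)[C@H]2O)c2ncnc(OC)c12`, with ethynyl in that place, gives 4060 nM. For the measured compounds named here, that pair shows a 3.4-fold lower number from compound 1 to compound 2 (0.53 log units; beyond the scatter), so the group entering compound 4 belongs to the weaker member of the only measured pair, and the gap between them is modest.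

With compound 1 at 13800 nM, nothing points to a large gain, and only a small move toward a lower number is expected. The expected change is an at least 1.4-fold lower number from compound 3 to compound 4 (0.15 log units; that floor lies within the scatter). A second result reported only as a limit would be no surprise. The estimate for compound 4 is 14000 nM, within an expected range of 4000 nM to 40000 nM.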

Compound 4, half-maximal inhibitory concentration: > 20000 nM
Compound 4 was reported as a limit; the forecaster's own chance of this, stated with the estimate: 55%; middle value at least 1.4-fold (0.15 log units) from the limit.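

Compound 3 and compound 4 are both reported only as limits in this assay and so the step between them, 1-benzofuran-2-yl in place of furan-2-yl, cannot be read. The compounds shown leave open whether this exchange on the shared core changes the result at all, and how far each compound lies past its limit.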